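Swapping one fluorinated group for trifluoromethyl

The source may report more compounds than this note shows. Statements on the series, on what has been measured and on what is new or still open speak of the compounds shown alone.

Compound 1 `CC(O)(COc1ccc(S(F)(F)(F)(F)F)cc1)C(=O)Nc1ccc(S(F)(F)(F)(F)F)cc1` gives 13000 nM
Compound 2 `CC(O)(COc1ccc(C#N)cc1)C(=O)Nc1ccc(S(F)(F)(F)(F)F)cc1` gives 26100 nM

For the measured compounds named here, in a functional assay on CWR22R cells (Homo sapiens) for antiproliferative activity, read by propidium iodide staining, with a stated time of 96 h (a higher number here means a weaker inhibitor, a lower number a stronger inhibitor), compound 1 gives (13000 nM) and stands level with compound 2, the only other compound measured so far, since the gap between them lies within the scatter. Compound 3 `CC(O)(COc1ccc(S(F)(F)(F)(F)F)cc1)C(=O)Nc1ccc(C(F)(F)F)cc1` has not yet been measured. Its change from compound 1 is this: a group of 4 heavy atoms (1 carbon, 3 fluorine; no ring) in place of a group of 6 heavy atoms (5 fluorine, 1 sulfur; no ring), on an aromatic carbon (trifluoromethyl enters, and the group of 6 heavy atoms leaves).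

Going by the values given here, only one measured step bears on this change: a 2.0-fold higher number from compound 1 to compound 2 (0.30 log units; within the scatter). There the same group of 6 heavy atoms was replaced by a different group on another aromatic carbon of the molecule, and the number stayed within the scatter. Among the compounds with values here, that is indirect evidence, as no step has been measured at the aromatic carbon that changes in compound 3. A step beyond the scatter is therefore not expected, though the uncertainty stays wide. The expected step in this assay is small (a 1.2-fold higher number from compound 1 to compound 3 (0.06 log units; within the scatter)). Compound 3 is estimated at 15000 nM with an expected range (6000 nM to 40000 nM).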

Compound 3, half-maximal inhibitory concentration: 12900 nM
Beside the measured number, compound 3's estimate is 1.2-fold (0.07 log units) above it; the measured number falls inside the stated range.
By their numbers in this assay, from the lowest: compounds 3, 1 and 2 (each within the scatter of the next, the first and the last beyond it).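

In this assay, for the compounds shown here, the first step at this aromatic carbon, para to a large group, is a 1.0-fold lower number from compound 1 to compound 3 (0.00 log units; within the scatter). Trifluoromethyl, with 4 heavy atoms, can therefore stand in place of the group of 6 heavy atoms (5 fluorine, 1 sulfur) here without a step beyond the scatter, which compounds 1 and 2 could not show because their only step lies on another aromatic carbon of the molecule. Nothing measured here offers an explanation for how closely compound 1 and compound 3 agree.

Going by these compounds, both groups exchanged at this carbon contain fluorine, have no ring and count 0 hydrogen-bond donors and 0 hydrogen-bond acceptors, so the result covers only a narrow kind of replacement, and it remains open whether a group of a different make-up, such as an amine, a carboxylic acid or a simple hydrogen atom, would also stay within the scatter here. On these data alone, it also remains open whether trifluoromethyl would give a similarly small step on the other aromatic carbon, where compound 1 carries the same group of 6 heavy atoms.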